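A Methyl Added to the Quaternary Centre of Compound 2

This account rests on a few compounds, and the source may have more. Where it says the series, first, only, none or still open, it means among the compounds named here.

This account concerns two small diamino acids measured in an assay for inhibition of Ornithine decarboxylase (Rattus norvegicus) (a higher number here means a weaker inhibitor, a lower number a stronger inhibitor), and another that has not yet been measured. Compound 2 `CC(CN)C(C)(CN)C(=O)O` gives 1650000 nM in this assay, the only number shown, so there is nothing numerical to rank it against. Compound 1 `CC(C)(CN)C(CN)C(=O)O` gives > 11000000 nM in this assay, which is a limit of the assay and not a number. Compound 1 thus stands at the limit of > 11000000 nM in this assay, at which 1 of the 2 values shown sits.

Compound 3 `CC(C)(CN)C(C)(CN)C(=O)O` differs from compound 2 by methyl in place of hydrogen on a saturated chain carbon bound to three saturated chain carbons. Among the compounds with values here, no step between measured compounds that differ in one place is available, so the size of such a change has not been observed directly in this assay. The expectation is that the step from compound 2 to compound 3 lies somewhat beyond the usual scatter and runs toward weaker inhibition, as a 3.0-fold higher number from compound 2 to compound 3 (0.48 log units; beyond the scatter) expresses. Compound 3 is therefore estimated at 5000000 nM, with a range from 1200000 nM to 25000000 nM, and with a real chance that this assay returns only a limit for it.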

Compound 3, inhibition constant: > 11000000 nM
Compound 3: a limit, no number (the forecaster's own chance of this, stated with the estimate: 45%); at least 2.2-fold (0.34 log units) between middle value and limit.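

In this assay compound 3 gives > 11000000 nM, which is a limit of the assay and not a number. Even so, methyl in place of hydrogen on a saturated chain carbon bound to three saturated chain carbons now has a readable step of its own, the first in this small set: an at least 6.6-fold higher number from compound 2 to compound 3 (0.82 log units; beyond the scatter) shows that this change runs toward weaker inhibition and that it lies beyond the scatter, although only its lower bound is known. The other step, methyl in place of hydrogen on a saturated chain carbon bound to a carbonyl carbon and two saturated chain carbons, cannot be read, since both of its ends are limits, and compound 3 now stands with compound 1 at the same ceiling: the limit of > 11000000 nM in this assay, at which 2 of the 3 values shown sit.

Going by these compounds, how far compound 3 really lies past that limit stays open, and with it the true size of the step from compound 2. The compounds shown also leave open whether an ethyl group in place of this methyl, a phosphonic acid in place of the carboxylic acid, or a longer chain carrying the amine would bring a value back into the measurable range.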